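Ethyl to tert-Butyl on a Phenyl Urea

The compounds below may be only part of what the source reports. "The series", "measured", "known", "first", "only" and "open" are said of these compounds alone.

The series consists of three ureas carrying an ethyl-substituted phenyl ring. Compound 1 `CCc1ccccc1NC(=O)N[C@H](C)c1ccccc1` gives 101% in an ADME assay on the whole organism with Oryza sativa as the target, tested at 0.1 uM; a lower number here means a stronger effect, a higher number a weaker effect of the compound at the concentration tested. Compound 2 `CCc1ccc(NC(=O)N[C@H](C)c2ccccc2)cc1` gives 95%, and compound 3 `CCc1ccc(NC(=O)N[C@@H](C)c2ccccc2)cc1` gives 99%. Among the three numbers, compound 3 stands second highest, with compound 1 just above it and compound 2 just below it, both gaps lying within the scatter. Among the measured compounds shown here, the only single-point step among the measured compounds is a number 4 percentage points higher from compound 2 to compound 3 (within the scatter), and it is explained by the fact that compounds 2 and 3 differ only in the configuration as drawn.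

Compound 4 `C[C@H](NC(=O)Nc1ccc(C(C)(C)C)cc1)c1ccccc1` is the next member, differing from compound 3 by tert-butyl in place of ethyl on an aromatic carbon. For the measured compounds named here, no measured step bears on this change: the one step on record concerns configuration alone, and no pair of measured compounds varies the alkyl group on the aromatic ring. With the three measured numbers lying within the scatter of one another, the expectation for compound 4 is a step of a number 2 percentage points lower from compound 3 to compound 4 (within the scatter), that is, none beyond the scatter. Compound 4 is therefore estimated at 97%, with a likely range from 85% to 106%.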

Compound 4, a percentage reported as activity, at one concentration (the size of the read-out at that concentration, not a potency): 100%
Beside the measured number, compound 4's estimate is 3 percentage points below it; the range from low to high includes it.
By their numbers in this assay, from the lowest: compounds 2, 3, 4 and 1 (each within the scatter of the next).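

Among the compounds shown here, compound 4 gives the only measured comparison of alkyl groups at this place, on an aromatic carbon of the ring and para to a large group. In this assay, tert-butyl (4 heavy atoms) in place of ethyl (2 heavy atoms) gives a number 1 percentage points higher from compound 3 to compound 4 (within the scatter), so at the concentration tested the read-out does not separate the two alkyl groups, even though the entering group is larger and branched. Nothing available explains why this exchange leaves the read-out within the scatter.

The compounds shown leave open whether a group of another kind at this place, such as a methoxy group, an amine or a carboxylic acid, would shift the number beyond the scatter. They also leave open whether ethyl and tert-butyl would remain indistinguishable at any other concentration.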